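Trifluoromethoxy in place of cyano on compound 1

The source may hold more compounds than are shown below. What is called first, only, known or untested is meant among the compounds shown, and "the series" means these compounds.

Going by the values given here, in a functional assay on NALM-6 cells (Homo sapiens) for cytotoxicity, read by luminescence and CellTiter-Glo, with a stated time of 3 days (a higher number here means a weaker inhibitor, a lower number a stronger inhibitor), compound 1 (`N#Cc1ccc(NC(=O)c2cc(Cl)ccc2O)c(Cl)c1`) gives 730 nM as the higher of the two numbers so far, and compound 2 (`N#Cc1cc(Cl)ccc1NC(=O)c1ccc2cccnc2c1O`) gives 280 nM with a gap beyond the scatter. Compound 3 (`O=C(Nc1ccc(OC(F)(F)F)cc1Cl)c1cc(Cl)ccc1O`) carries trifluoromethoxy in place of cyano on an aromatic carbon of the core of compound 1, meta to a chloro group and para to a large group. Among the compounds with values here, no measured step covers this change, so no shift beyond the scatter is expected in this assay (a 1.2-fold lower number from compound 1 to compound 3 (0.09 log units; within the scatter)). Compound 3 is estimated at 600 nM (range 200 nM to 1800 nM).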

Compound 3, half-maximal inhibitory concentration: 1350 nM
Compound 3: middle estimate off by 2.3-fold (0.35 log units), on the low side, within the range that was stated.
By their numbers in this assay, from the lowest: compound 2; then compounds 1 and 3 (each within the scatter of the next).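

In this assay trifluoromethoxy in place of cyano on an aromatic carbon, meta to a chloro group and para to a large group, brings no shift beyond the scatter (a 1.8-fold higher number from compound 1 to compound 3 (0.27 log units; within the scatter)). This position thus carries a group of five heavy atoms as well as one of two, and in this pair the nitrile is not required for the read-out. Nothing measured here accounts for this result. As far as these compounds go, whether an amine, a carboxylic acid or a longer chain is carried equally well at this position stays open.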